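The compounds below may be only part of what the source reports. "The series", "measured", "known", "first", "only" and "open" are said of these compounds alone.

Measured so far in a functional assay on ECa-109 cells (Homo sapiens) for inhibition, read by MTT assay, with a stated time of 72 h; a lower number here means a stronger inhibitor, a higher number a weaker inhibitor:
Compound 1 `N#Cc1c(Nc2cccc(C(F)(F)F)c2)nc(SCc2cn(Cc3ccccc3Cl)nn2)nc1-c1ccccc1` gives 32000 nM.
Compound 2 `Cc1ccc(Cn2cc(CSc3nc(Nc4ccccc4C)c(C#N)c(-c4ccccc4)n3)nn2)cc1` reaches only the limit of the assay, > 64000 nM.
Compound 3 `N#Cc1c(Nc2ccccc2F)nc(SCc2cn(Cc3ccc(Cl)cc3)nn2)nc1-c1ccccc1` likewise reaches only the limit of the assay, > 64000 nM.

For the measured compounds named here, compound 1 stands as the only measured number among the three; the other two results are limits, not numbers. The weight of the data sits at the limit of > 64000 nM in this assay, at which 2 of the 3 values shown sit, so the shared core of compound 1 appears weak in this assay across the three compounds.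

Compound 4 `Cc1ccc(Nc2nc(SCc3cn(Cc4ccccc4Cl)nn3)nc(-c3ccccc3)c2C#N)cc1` is not yet measured. It differs from compound 1 in one place: 4-methylphenyl in place of 3-(trifluoromethyl)phenyl on a nitrogen on an aromatic ring. Going by the values given here, no measured pair with a single change is available, so the size of this step cannot be read from the data. Given that the two compounds with methyl or fluorine on the anilino ring, compound 2 and compound 3, sit at the limit, compound 4 is expected to be weaker than or close to compound 1, with the step from compound 1 to compound 4 estimated at a 1.7-fold higher number from compound 1 to compound 4 (0.24 log units; within the scatter). Compound 4 is therefore estimated at 55000 nM, within a range from 20000 nM to 150000 nM.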

Compound 4, half-maximal inhibitory concentration: > 64000 nM
Compound 4: no number, only a limit (the forecaster's own chance of this, stated with the estimate: 45%); middle value at least 1.1-fold (0.06 log units) from the limit.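

In this assay, compound 4 gives only a limit of the assay, > 64000 nM, not a number. For the compounds shown here, this is the first change in a single place that can be read: 4-methylphenyl in place of 3-(trifluoromethyl)phenyl on a nitrogen on an aromatic ring gives an at least 2.0-fold higher number from compound 1 to compound 4 (0.30 log units; that floor lies within the scatter), so the step has a floor but no measured size, and that floor does not establish a real difference. Compound 1 remains the only one of the four compounds with a number, and the series still looks weak: the limit of > 64000 nM in this assay, at which 3 of the 4 values shown sit.

The compounds shown leave open whether an amine or a carboxylic acid on this phenyl ring would bring a value back within the measurable range of this assay. They also leave open how large the step really is, since compound 4 has only a limit.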